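The source may hold more compounds than are shown below. What is called first, only, known or untested is meant among the compounds shown, and "the series" means these compounds.

Working notes on the series. All compounds share one core, varied only in the aryl group on the amide carbonyl. In an in vitro assay on FRT cells with Cystic fibrosis transmembrane conductance regulator variant F508del (Homo sapiens) as the target, read by fluorescence, with a stated time of 24 h, at 37 degrees C, in the presence of a further agent that is not named here (a lower number here means that less compound is needed, a higher number that more compound is needed for the effect), compound 1 `COc1ccccc1C(=O)NCCCNc1nc2cc(C)cc(C)c2cc1C#N` is reported as "not active" (no number reported). Compound 2 `COc1cccc(C(=O)NCCCNc2nc3cc(C)cc(C)c3cc2C#N)c1` gives 4600 nM and compound 3 `COc1ccc(C(=O)NCCCNc2nc3cc(C)cc(C)c3cc2C#N)cc1` gives 4300 nM. Within the data shown here, compound 3 thus stands at one of only two numbers reported; the step of a 1.1-fold lower number from compound 2 to compound 3 (0.03 log units; within the scatter) lies within the scatter, and the remaining entry carries no number.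

Compound 4 `Cc1cc(C)c2cc(C#N)c(NCCCNC(=O)c3ccccn3)nc2c1` differs from compound 3 by pyridin-2-yl in place of 4-methoxyphenyl on a carbonyl carbon. Among the measured compounds shown here, the single measured step, from compound 2 to compound 3, only shifts a methoxy group on a phenyl ring and does not exchange the ring, so no measured step bears directly on this change. With nothing shown to move the number, the expected step of no change at the digits printed from compound 3 to compound 4 (within the scatter) is none beyond the scatter. Compound 4 is therefore estimated at 4300 nM, range 1500 nM to 15000 nM, with a real chance it returns without a number, as compound 1 did.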

Compound 4, half-maximal effective concentration: "not active" (no number reported)
No number was reported for compound 4, so the estimate cannot be set against anything.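

Among these compounds, compound 4 gives "not active" (no number reported) in this assay, so no step from compound 3 to compound 4 can be read, and nothing available bears on this result. The compounds shown leave open whether a pyridin-2-yl amide can give a number under any other change to the series.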